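Varying the Sulfonyl Substituent: What to Expect for Compound 4

The compounds below may be only part of what the source reports. "The series", "measured", "known", "first", "only" and "open" are said of these compounds alone.

The three measured compounds share one core and differ only at the sulfonyl sulfur. In an assay on CHO cells for displacement of a labelled ligand from prostaglandin D2 receptor 2 (Homo sapiens), read by scintillation counting (a lower number here means a stronger inhibitor, a higher number a weaker inhibitor), compound 1 `COCCN(C)S(=O)(=O)c1ccc(C)c(C#Cc2cc(Cl)ccc2OCC(=O)O)c1` gives 4.1 nM. Compound 2 `Cc1ccc(S(=O)(=O)NC(C)C)cc1C#Cc1cc(Cl)ccc1OCC(=O)O` gives 3.4 nM in this assay. Compound 3 `Cc1ccc(S(=O)(=O)CC(C)C)cc1C#Cc1cc(Cl)ccc1OCC(=O)O` gives 3 nM and thus holds the lowest of the three numbers, yet a 1.4-fold lower number from compound 1 to compound 3 (0.14 log units; within the scatter) and a 1.1-fold lower number from compound 2 to compound 3 (0.05 log units; within the scatter) both lie within the scatter, as does a 1.2-fold lower number from compound 1 to compound 2 (0.08 log units; within the scatter), so none of the three can be called the stronger inhibitor.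

Compound 4 `CCN(CC)S(=O)(=O)c1ccc(C)c(C#Cc2cc(Cl)ccc2OCC(=O)O)c1` carries the next variant at the same place: diethylamino in place of isobutyl on a sulfonyl sulfur. Among the compounds with values here, the steps that bear on it are the three exchanges at the sulfonyl sulfur, each within the scatter, and the entering diethylamino is an amino substituent like those of compound 1 and compound 2. Compound 4 is therefore expected to show a 1.2-fold higher number from compound 3 to compound 4 (0.07 log units; within the scatter), no shift beyond the scatter. Compound 4 is estimated at 3.5 nM, with a range from 1.5 nM to 8 nM.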

Compound 4, inhibition constant: 3.4 nM
The estimate for compound 4 lay 1.0-fold (0.01 log units) above the measured number; the range from low to high includes it.
By their numbers in this assay, from the lowest: compounds 3, 2, 4 and 1 (each within the scatter of the next).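

Placing diethylamino on a sulfonyl sulfur in place of isobutyl, the isobutylsulfonyl to diethylsulfamoyl exchange, gives a 1.1-fold higher number from compound 3 to compound 4 (0.05 log units; within the scatter) in this assay and this step stays within the scatter. Against the two other amino substituents the picture is the same, with no change at the digits printed from compound 2 to compound 4 (within the scatter) and a 1.2-fold lower number from compound 1 to compound 4 (0.08 log units; within the scatter) both printed as within the scatter. All four substituents on this sulfur, whether joined through carbon or through nitrogen, therefore give numbers that cannot be told apart, and the added nitrogen of diethylamino shows no effect beyond the scatter; the data offer no explanation for this.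

What the compounds leave open is whether a piperidine or morpholine ring on the sulfonyl sulfur, or a carboxylic acid on a longer chain there, would move the number beyond the scatter. Changes elsewhere on the shared core also remain open.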